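This account rests on a few compounds, and the source may have more. Where it says the series, first, only, none or still open, it means among the compounds named here.

Compound 1, `O=C1c2cccc(O)c2C(=O)C1(O)O`: > 100000 nM
Compound 2, `CC(C)Oc1cccc2c1C(=O)C(O)(O)C2=O`: > 100000 nM
Compound 3, `COc1cccc2c1C(=O)C(O)(O)C2=O`: > 100000 nM

The three measured compounds share one core and differ only in the group on an oxygen on the aromatic ring. In an assay on isolated protein for inhibition of carbonic anhydrase 4 (Homo sapiens), read by stopped-flow, with a stated time of 15 min (on this read-out higher numbers stand for weaker inhibition and lower numbers for stronger inhibition), compound 1 gives > 100000 nM, which is a limit of the assay and not a number. Compound 2 gives > 100000 nM, again a limit. Compound 3 gives > 100000 nM, also a limit. So compound 3 stands nowhere that can be placed exactly: its value is known only as a limit, and the two other values are limits as well. For that reason the steps a step that the two limits leave unreadable from compound 1 to compound 2, a step that the two limits leave unreadable from compound 1 to compound 3 and a step that the two limits leave unreadable from compound 2 to compound 3 cannot be read at all; all that is known is the limit of > 100000 nM in this assay, at which 3 of the 3 values shown sit.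

Compound 4, `O=C1c2cccc(Br)c2C(=O)C1(O)O`, has not yet been measured in this assay. It differs from compound 3 by bromo in place of methoxy on an aromatic carbon. Among the measured compounds shown here, no measured step bears readably on this change. For the measured compounds named here, since every value so far sits at the limit of > 100000 nM in this assay, at which 3 of the 3 values shown sit, compound 4 is expected to sit there too, with an expected step of a number no higher from compound 3 to compound 4 (the limit leaves the size open). Compound 4 is therefore estimated at 100000 nM, in a range from 30000 nM to 300000 nM, most probably reported only as a limit.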

Compound 4, inhibition constant: > 100000 nM
Compound 4 was reported as a limit; the forecaster's own chance of this, stated with the estimate: 80%; the middle value sits exactly at the limit.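

The result for compound 4 is again a limit, so the steps to compound 4 from compound 1, compound 2 and compound 3 cannot be read, because all four compounds share one limit: the limit of > 100000 nM in this assay, at which 4 of the 4 values shown sit. The compounds shown leave open whether the hydroxy, isopropoxy, methoxy and bromo groups differ at all in this assay.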